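This account rests on a few compounds, and the source may have more. Where it says the series, first, only, none or still open, it means among the compounds named here.

Measured so far:
Compound 1, `CC(=O)Nc1cccc(S(=O)(=O)Oc2ccccc2C(C)C)c1`: 31000 nM
Compound 2, `CCCC(=O)Nc1cccc(S(=O)(=O)Oc2ccccc2C(C)C)c1`: 20000 nM
Compound 3, `CC(C)C(=O)Nc1cccc(S(=O)(=O)Oc2ccccc2C(C)C)c1`: 17000 nM

These three compounds share one core and differ only in the group attached to the carbonyl carbon of the amide. In a functional assay on M21 cells (Homo sapiens) for antiproliferative activity, read by sulforhodamine B assay, with a stated time of 48 h (a lower number here means a stronger inhibitor, a higher number a weaker inhibitor), compound 2 gives 20000 nM, the second highest of the three numbers; its nearest neighbour is compound 3 and its furthest is compound 1, and both gaps, a 1.2-fold lower number from compound 2 to compound 3 (0.07 log units; within the scatter) and a 1.6-fold lower number from compound 1 to compound 2 (0.19 log units; within the scatter), lie within the scatter. Compound 4, `CC(C)c1ccccc1OS(=O)(=O)c1cccc(NC(=O)C(C)(C)C)c1`, has not yet been measured. It differs from compound 2 in one place: tert-butyl in place of propyl on a carbonyl carbon. Within the data shown here, two measured steps bear on this change, since each also enlarges or branches the group on the carbonyl carbon: a 1.8-fold lower number from compound 1 to compound 3 (0.26 log units; within the scatter) and a 1.2-fold lower number from compound 2 to compound 3 (0.07 log units; within the scatter). Neither moved the number beyond the scatter, and the remaining step, a 1.6-fold lower number from compound 1 to compound 2 (0.19 log units; within the scatter), was likewise small. Putting tert-butyl in place of propyl is thus expected to give at most a modest shift towards a lower number. The step expected for compound 4 is accordingly small, a 1.3-fold lower number from compound 2 to compound 4 (0.12 log units; within the scatter). For compound 4 in this assay the estimate is 15000 nM, with a range from 7000 nM to 35000 nM.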

Compound 4, half-maximal inhibitory concentration: 13000 nM
Compound 4: middle estimate off by 1.2-fold (0.06 log units), on the high side, and the stated range covers the measured number.
By their numbers in this assay, from the lowest: compounds 4, 3, 2 and 1 (each within the scatter of the next, the first and the last beyond it).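

In this assay, among these compounds, tert-butyl on the carbonyl carbon gives the only step in this set that lies beyond the scatter: a 2.4-fold lower number from compound 1 to compound 4 (0.38 log units; beyond the scatter), a modest change. The steps from the propyl and isopropyl compounds stay within the scatter, at a 1.5-fold lower number from compound 2 to compound 4 (0.19 log units; within the scatter) and a 1.3-fold lower number from compound 3 to compound 4 (0.12 log units; within the scatter), so only the methyl and tert-butyl ends of the series can be told apart. This position therefore accepts tert-butyl with no rise in the number, but nothing shown gives a reason for the one step beyond the scatter.

Going by these compounds, with only these four compounds, all carrying plain carbon groups on the carbonyl carbon, it remains open whether the number would keep falling with a longer chain, such as hexyl, or would rise again. On these data alone, it also remains open how this position would respond to a group with other atoms in it, such as an amine or a carboxylic acid.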